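The source may hold more compounds than are shown below. What is called first, only, known or untested is meant among the compounds shown, and "the series" means these compounds.

Of the compounds shown here, three sharing one core have been tested in a functional assay on Caco-2 cells (Homo sapiens), read by MTT assay, with a stated time of 48 h; on this read-out higher numbers stand for weaker inhibition and lower numbers for stronger inhibition. Compound 1 `CCOC(=O)CN(C)C(=O)c1ccc(C(CC)(CC)c2ccc(OCC(O)C(C)(C)C)c(C)c2)n1CC` gives 12200 nM, compound 2 `CCn1c(C(=O)NCCN(C)C)ccc1C(CC)(CC)c1ccc(OCC(O)C(C)(C)C)c(C)c1` gives 1300 nM, and compound 3 `C#CCNC(=O)c1ccc(C(CC)(CC)c2ccc(OCC(O)C(C)(C)C)c(C)c2)n1CC` gives 39100 nM, the highest of the three numbers, with a 3.2-fold higher number from compound 1 to compound 3 (0.51 log units; beyond the scatter) and a 30-fold higher number from compound 2 to compound 3 (1.48 log units; beyond the scatter). Compound 4 `CCn1c(C(=O)N(C)CCC#N)ccc1C(CC)(CC)c1ccc(OCC(O)C(C)(C)C)c(C)c1` differs from compound 3 at the carbonyl carbon: (2-cyanoethyl)(methyl)amino in place of propargylamino on a carbonyl carbon. The step that bears most closely on this is a 3.2-fold higher number from compound 1 to compound 3 (0.51 log units; beyond the scatter), since the group entering compound 4, like that of compound 1, is named with a methyl on the nitrogen; the far larger a 30-fold higher number from compound 2 to compound 3 (1.48 log units; beyond the scatter) involved a (dimethylamino)methyl group that compound 4 lacks. A modest lowering of the number is therefore expected, a 2.6-fold lower number from compound 3 to compound 4 (0.42 log units; beyond the scatter). Compound 4 is estimated at 15000 nM, within a range from 5000 nM to 45000 nM.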

Compound 4, half-maximal inhibitory concentration: > 50000 nM
Compound 4: only a limit was reported; the forecaster's own chance of this, stated with the estimate: 5%; middle value at least 3.3-fold (0.52 log units) from the limit.
By their numbers in this assay, from the lowest: compound 2; then compound 1; then compound 3. At a limit, above all of these: compound 4.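

Compound 4 gives only a limit, not a number: the limit of > 50000 nM in this assay, at which 1 of the 4 values shown sits. Against propargylamino, (2-cyanoethyl)(methyl)amino on this carbonyl carbon gives an at least 1.2-fold higher number from compound 3 to compound 4 (0.10 log units; that floor lies within the scatter), so this floor does not separate the two compounds. Within the data shown here, the wider gaps are an at least 38-fold higher number from compound 2 to compound 4 (1.58 log units; beyond the scatter) and an at least 4.0-fold higher number from compound 1 to compound 4 (0.61 log units; beyond the scatter), which leaves the (2-(dimethylamino)ethyl)amino group of compound 2 with the lowest number so far.

From the compounds shown here alone, how far the true value of compound 4 lies past its limit stays open. Also open, going by these compounds, is whether a longer chain ending in the same dimethylamino group, or in a primary amine, would keep a number as low as that of compound 2.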